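This account rests on a few compounds, and the source may have more. Where it says the series, first, only, none or still open, it means among the compounds named here.

In a functional assay on MC-38 cells (Mus musculus) for antiproliferative activity (a higher number here means a weaker inhibitor, a lower number a stronger inhibitor), compound 1 `Cc1ccc(S(=O)(=O)Nc2cccc3cc[nH]c23)cc1` gives 2.4 ug/mL, compound 2 `N#Cc1ccc(S(=O)(=O)Nc2cccc3cc[nH]c23)cc1` gives 1.8 ug/mL and compound 3 `Nc1ccc(S(=O)(=O)Nc2cccc3cc[nH]c23)cc1` gives 6.1 ug/mL. There is a 1.3-fold lower number from compound 1 to compound 2 (0.12 log units; within the scatter), so that pair cannot be separated. Against that, there is a 3.4-fold higher number from compound 2 to compound 3 (0.53 log units; beyond the scatter), and also a 2.5-fold higher number from compound 1 to compound 3 (0.41 log units; beyond the scatter). Compound 4 `N#Cc1ccc(S(=O)(=O)Nc2cccc3c(Cl)c[nH]c23)cc1` differs from compound 2 by chloro in place of hydrogen on an aromatic carbon. Within the data shown here, no measured step changes that carbon, so these steps offer only a rough guide to size, and none shows the direction. A modest drop is a tentative expectation, comparable in size to the measured steps. The expected change is a 1.8-fold lower number from compound 2 to compound 4 (0.26 log units; within the scatter). For compound 4, the estimated value is 1 ug/mL, with an expected range of 0.3 ug/mL to 2.5 ug/mL.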

Compound 4, half-maximal inhibitory concentration: 0.13 ug/mL
Beside the measured number, compound 4's estimate is 7.7-fold (0.89 log units) above it; measured number outside the range, below it.
By their numbers in this assay, from the lowest: compound 4; then compounds 2 and 1 (each within the scatter of the next); then compound 3.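

In this assay, chloro in place of hydrogen on this carbon of the five-membered ring gives a 14-fold lower number from compound 2 to compound 4 (1.14 log units; beyond the scatter). Among these compounds, this carbon does not change among the earlier compounds, and the step here is larger than their largest step, a 3.4-fold higher number from compound 2 to compound 3 (0.53 log units; beyond the scatter), which changes a group elsewhere in the molecule. No measurement shown here accounts for the size of this drop.

From the compounds shown here alone, it remains open whether bromo, fluoro or methyl on the same carbon would give a similar drop. Going by these compounds, it is also open whether chloro would do the same with methyl or amino in place of cyano.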